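The source may hold more compounds than are shown below. What is called first, only, known or untested is meant among the compounds shown, and "the series" means these compounds.

Among the measured compounds shown here, in a functional assay on MCF7 cells (Homo sapiens) for cytotoxicity, read by MTT assay, with a stated time of 72 h (on this read-out lower numbers stand for stronger inhibition and higher numbers for weaker inhibition), compound 1 (`CN(C)CCCNc1c(C(=O)NCc2ccc(F)cc2)nc(Br)c2cccnc12`) gives 7000 nM and holds the only number so far. In this assay compound 2 (`O=C(NCc1ccc(F)cc1)c1nc(Br)c2cccnc2c1NCCO`) has the entry "not determined" (no result reported) and no number. In this assay compound 3 (`CNc1c(C(=O)NCc2ccc(F)cc2)nc(Br)c2cccnc12`) has the entry "not determined" (no result reported) as well, so it stands without a single number and offers no measured starting level.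

Compound 4 (`CNCCCNc1c(C(=O)NCc2ccc(F)cc2)nc(Br)c2cccnc12`) has yet to be measured. One structural change leads to it (2-(methylamino)ethyl in place of hydrogen on a saturated chain carbon bound to a nitrogen on an aromatic ring): 2-(methylamino)ethyl takes the place of hydrogen on a saturated chain carbon bound to a nitrogen on an aromatic ring, which turns methylamino into (3-(methylamino)propyl)amino.

Without a number for compound 3, the size of this step in this assay cannot be read. The expectation therefore leans on compound 1 at 7000 nM and foresees no shift beyond the scatter from that number, in either direction. In this assay the estimated value for compound 4 is 6000 nM with an expected range from 2000 nM to 20000 nM around that middle.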

Compound 4, half-maximal inhibitory concentration: > 10000 nM
Compound 4: no number, only a limit (the forecaster's own chance of this, stated with the estimate: 15%); middle value at least 1.6-fold (0.22 log units) from the limit.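

In this assay compound 4 carries only a limit, > 10000 nM, and not a number. Hydrogen in place of methyl on an amine nitrogen gives an at least 1.4-fold higher number from compound 1 to compound 4 (0.15 log units; that floor lies within the scatter), so no shift beyond the scatter can be claimed for this change, though a larger one is not ruled out. Adding 2-(methylamino)ethyl at this place is a step that cannot be read, and the comparison with the other chain-bearing compound rests on a limit: the limit of > 10000 nM in this assay, at which 1 of the 4 values shown sits.

Going by these compounds, how compound 2 and compound 3 would stand in this assay remains open. Also open, on these data alone, is how a primary amine at this position, or a longer chain carrying the methylamino group, would read against these values.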